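From 4-Methylpiperidine to a Hydroxyethyl Piperidine

The compounds below may be only part of what the source reports. "The series", "measured", "known", "first", "only" and "open" are said of these compounds alone.

- compound 1 `COc1cc2c(Nc3ccc(C#N)cc3)ncnc2cc1OCCCN(C)C` gives 60500 nM
- compound 2 `COc1cc2c(Nc3ccc(C#N)cc3)ncnc2cc1OCCCN1CCC(C)CC1` gives 32300 nM

In a functional assay on A549 cells (Homo sapiens) for antiproliferative activity, read by MTT assay, with a stated time of 72 h (a lower number here means a stronger inhibitor, a higher number a weaker inhibitor), compound 2 gives 32300 nM and so stands within the scatter of compound 1. Compound 3 `COc1cc2c(Nc3ccc(C#N)cc3)ncnc2cc1OCCCN1CCCCC1CCO` keeps the shared core and the chain and changes one group, a swap counted as 2-(2-hydroxyethyl)piperidin-1-yl in place of 4-methylpiperidin-1-yl on a saturated chain carbon, three bonds along the chain from an oxygen on an aromatic ring on a saturated chain carbon, three bonds along the chain from an oxygen on an aromatic ring. Among the compounds with values here, one measured step bears on this, a 1.9-fold lower number from compound 1 to compound 2 (0.27 log units; within the scatter) at that same place, and it lies within the scatter. Within the data shown here, no measured compound carries the 2-(2-hydroxyethyl)piperidin-1-yl group, so this support is thin. No change beyond the scatter is expected in this assay for now. The expected step is a 1.1-fold lower number from compound 2 to compound 3 (0.03 log units; within the scatter) and no more. Compound 3 is estimated at 30000 nM with 12000 nM to 70000 nM as the expected range.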

Compound 3, half-maximal inhibitory concentration: > 100000 nM
Compound 3: no number, only a limit; the forecaster's own chance of this, stated with the estimate: 10%; middle value at least 3.3-fold (0.52 log units) away from the limit.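

For compound 3, the reading is a limit rather than a number: the limit of > 100000 nM in this assay, at which 1 of the 3 values shown sits. Even so, this place on the chain is not indifferent to the group it carries: 2-(2-hydroxyethyl)piperidin-1-yl in place of 4-methylpiperidin-1-yl gives a change beyond the scatter (an at least 3.0-fold higher number from compound 2 to compound 3 (0.49 log units; beyond the scatter)), which the earlier step did not. Against dimethylamino, the floor does not clear the scatter (an at least 1.6-fold higher number from compound 1 to compound 3 (0.21 log units; that floor lies within the scatter)).

The compounds shown leave open whether this rise goes with the hydroxyl or with the carbon chain that holds it. A 2-ethylpiperidin-1-yl or 4-(2-hydroxyethyl)piperidin-1-yl group would help separate the two.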